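This account rests on a few compounds, and the source may have more. Where it says the series, first, only, none or still open, it means among the compounds named here.

Compound 1 `Cc1ccc(C(=O)Nc2cc(-c3ccccc3)nn2-c2ccccc2)cc1` — 30 nM
Compound 2 `O=C(Nc1cc(-c2ccccc2)nn1-c1ccccc1)c1ccccc1Cl` — 2500 nM
Compound 3 `O=C(Nc1cc(-c2ccccc2)nn1-c1ccccc1)c1ccccc1O` — a limit, > 10000 nM

In an assay on CHO cells with metabotropic glutamate receptor 5 (Homo sapiens) as the target (on this read-out lower numbers stand for an effect already at smaller amounts and higher numbers for an effect only at larger amounts of compound), compound 1, which carries 4-methylphenyl on the carbonyl carbon, gives 30 nM. Compound 2, which carries 2-chlorophenyl there, gives 2500 nM, the highest of the two numbers available. Compound 3 reaches only the limit of this assay, > 10000 nM (the limit of > 10000 nM in this assay, at which 1 of the 3 values shown sits). The steps among these three are all beyond the scatter: an 83-fold higher number from compound 1 to compound 2 (1.92 log units; beyond the scatter); an at least 330-fold higher number from compound 1 to compound 3 (2.52 log units; beyond the scatter); an at least 4.0-fold higher number from compound 2 to compound 3 (0.60 log units; beyond the scatter).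

Compound 4 `O=C(Nc1cc(-c2ccccc2)nn1-c1ccccc1)c1ccc(Cl)cc1` has not yet been measured in this assay. It differs from compound 2 by 4-chlorophenyl in place of 2-chlorophenyl on a carbonyl carbon. Within the data shown here, the step that bears on this change is the one from compound 1 to compound 2, where 2-chlorophenyl in place of 4-methylphenyl brought a large rise; compound 4 carries 4-chlorophenyl, a group set like the 4-methylphenyl of compound 1. The number for compound 4 is therefore expected to fall well below that of compound 2, with a 42-fold lower number from compound 2 to compound 4 (1.62 log units; beyond the scatter). Compound 4 is estimated at 60 nM, ranging from 15 nM to 400 nM.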

Compound 4, half-maximal effective concentration: 20 nM
Compound 4: middle estimate off by 3.0-fold (0.48 log units), on the high side; the range from low to high includes it.
By their numbers in this assay, from the lowest: compounds 4 and 1 (each within the scatter of the next); then compound 2. At a limit, above all of these: compound 3.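

Compound 2 and compound 4 have the same atoms joined differently, yet 4-chlorophenyl in place of 2-chlorophenyl on the carbonyl carbon brings a large drop in this assay (a 130-fold lower number from compound 2 to compound 4 (2.10 log units; beyond the scatter)). Compound 4 carries chloro as well and does not share the rise at compound 2. That rise goes with the 2-chlorophenyl group. Chloro in place of methyl leaves no readable difference (a 1.5-fold lower number from compound 1 to compound 4 (0.18 log units; within the scatter)), while the step from the 2-hydroxyphenyl group is a bound only (an at least 500-fold lower number from compound 3 to compound 4 (2.69 log units; beyond the scatter)) since compound 3 stands at a limit: the limit of > 10000 nM in this assay, at which 1 of the 4 values shown sits.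

Going by these compounds, whether an amine, a carboxylic acid or a longer chain in place of the chloro of compound 4 would hold its number stays open. So does the cause of the rise at compound 2, which these values do not tell.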